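Ethyl to Isopropyl on the Piperidine Nitrogen: Clearance Outlook

A few compounds are considered here, and "the series" means these few. Any claim that something is new, unique, unknown or untested is made for them only; others in the source may bear on it.

Compound 1 `C=CC(=O)Nc1cccc(-n2c(-c3nc(-c4cnn(C5CCN(C)CC5)c4)cnc3N)nc3ccccc32)c1` and compound 2 `C=CC(=O)Nc1cccc(-n2c(-c3nc(-c4cnn(C5CCN(CC)CC5)c4)cnc3N)nc3ccccc32)c1` share one core and differ only in the group on the piperidine nitrogen. In an ADME assay on liver for metabolic stability, with Liver microsome (Homo sapiens) as the target, using microsomes (on this read-out higher numbers stand for fast clearance and lower numbers for slow clearance), compound 1 gives 120 mL.min-1.g-1, and in this assay compound 2 gives 197 mL.min-1.g-1. The step of a 1.6-fold higher number from compound 1 to compound 2 (0.22 log units; within the scatter) is small. Going by the values given here, compound 2 therefore stands with the higher of the two numbers measured so far, but its nearest neighbour, compound 1, lies within the scatter of it, so no order between the two can be read.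

Compound 3 `C=CC(=O)Nc1cccc(-n2c(-c3nc(-c4cnn(C5CCN(C(C)C)CC5)c4)cnc3N)nc3ccccc32)c1` has not yet been measured. It differs from compound 2 by methyl in place of hydrogen on a saturated chain carbon bound to an amine nitrogen in a ring and a saturated chain carbon, which read one bond further out is ethyl to isopropyl, or 1-ethylpiperidin-4-yl to 1-isopropylpiperidin-4-yl. Among the compounds with values here, the only step that bears on this change is a 1.6-fold higher number from compound 1 to compound 2 (0.22 log units; within the scatter), where a methyl entered on the same kind of carbon; it stayed within the scatter. A step of similar size, and no larger, is expected here, in this assay as a 1.2-fold higher number from compound 2 to compound 3 (0.07 log units; within the scatter), with no clear direction beyond the scatter. Compound 3 is therefore estimated in this assay at 230 mL.min-1.g-1, within a range from 110 mL.min-1.g-1 to 460 mL.min-1.g-1.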

Compound 3, intrinsic clearance in microsomes in the Liver microsome assay: 37 mL.min-1.g-1
Beside the measured number, compound 3's estimate is 6.2-fold (0.79 log units) above it, and the stated range ends above it.
By their numbers in the Liver microsome assay, from the lowest: compound 3; then compounds 1 and 2 (each within the scatter of the next).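

Adding a methyl at this position does not always leave the clearance unchanged: in the Liver microsome assay, turning ethyl into isopropyl on the piperidine nitrogen gives a clear drop (a 5.3-fold lower number from compound 2 to compound 3 (0.73 log units; beyond the scatter)), whereas the methyl that turned methyl into ethyl on the same nitrogen did not (a 1.6-fold higher number from compound 1 to compound 2 (0.22 log units; within the scatter)). The isopropyl group also stands apart from the smaller methyl group (a 3.2-fold lower number from compound 1 to compound 3 (0.51 log units; beyond the scatter)), so compound 3 has the lowest number of the three, and its steps to both others lie beyond the scatter. The response at this position is therefore not a steady trend with each added carbon, since the methyl and ethyl compounds cannot be told apart while the isopropyl compound can, and nothing shown here gives a cause for that drop.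

In a physicochemical assay for solubility, at pH 7.4 (a lower number here means a less soluble compound, a higher number a more soluble compound), compound 2 gives < 10000 nM as a limit of the assay. In the physicochemical assay compound 3 gives < 10000 nM as a limit of the assay as well. In the physicochemical assay the step from ethyl to isopropyl cannot be read, because both compounds sit at a limit of the assay: the limit of < 10000 nM in the physicochemical assay, at which 2 of the 2 values shown sit.

From the compounds shown here alone, it remains open whether the low number in the Liver microsome assay holds with a tert-butyl or cyclopentyl group on the piperidine nitrogen, or is lost again with a longer chain such as n-propyl.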